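Swapping the acyl cap on the proline nitrogen

The compounds below may be only part of what the source reports. "The series", "measured", "known", "first", "only" and "open" are said of these compounds alone.

This account follows a series built on the shared core of compound 1 `CCOC(=O)/C=C/C(=O)N(CC(N)=O)NC(=O)[C@@H]1CCCN1C(=O)[C@H]1CCCCN1C(C)=O`, tested in an assay on isolated protein for inhibition of legumain (Mus musculus), read by fluorescence, with stated times of 30 s and 2.5 h; a higher number here means a weaker inhibitor, a lower number a stronger inhibitor. Among the measured compounds shown here, compound 1 is the only member with a definite number: in this assay compound 1 gives 638 nM. Compound 2 `CCOC(=O)/C=C/C(=O)N(CC(N)=O)NC(=O)[C@@H]1CCCN1C(=O)[C@@H]1Cc2ccccc2CN1C(C)=O` does not reach a number at all; in this assay compound 2 sits at the limit of > 1000 nM, which is a limit of the measurement rather than a value (the limit of > 1000 nM in this assay, at which 1 of the 2 values shown sits). For the measured compounds named here, no pair of measured compounds differs in a single place, so no measured step can be quoted.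

The untested compound 3 `CCOC(=O)/C=C/C(=O)N(CC(N)=O)NC(=O)[C@@H]1CCCN1C(=O)c1ccc(CNC(C)=O)cc1` differs from compound 1 in one place: a group of 11 heavy atoms (9 carbon, 1 nitrogen, 1 oxygen; one six-membered aromatic ring of carbon only) in place of a group of 9 heavy atoms (7 carbon, 1 nitrogen, 1 oxygen; one six-membered non-aromatic ring with 1 hetero atom), on a carbonyl carbon. Going by the values given here, with no measured step to lean on, the expected step of a 1.4-fold higher number from compound 1 to compound 3 (0.15 log units; within the scatter) is a modest loss, at the edge of the scatter. Compound 3 is therefore estimated at 900 nM, with a range from 300 nM to 3000 nM.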

Compound 3, half-maximal inhibitory concentration: 267 nM
The estimate for compound 3 lay 3.4-fold (0.53 log units) above the measured number; the whole stated range lies above it.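

Among the compounds shown here, the group on this carbonyl carbon, whose other neighbours are an amide-type nitrogen in a ring, need not be a six-membered non-aromatic ring with a defined stereocentre: in this assay the 4-(acetamidomethyl)phenyl group gives a 2.4-fold lower number from compound 1 to compound 3 (0.38 log units; beyond the scatter) and so provides the first measured step. This single change brings in a six-membered aromatic ring of carbon only and a hydrogen-bond donor and removes the stereocentre, so the step belongs to the exchange as a whole and cannot be assigned to any one of these features. Nothing shown here bears on the reason for the step.

The compounds shown leave open how much of the step depends on the acetamidomethyl arm, since none of them carries a plain phenyl group, a 4-(aminomethyl)phenyl group with its free amine, or a 4-carboxyphenyl group at this place. They also leave open whether a longer chain between the aromatic ring and the acetamide nitrogen would move the number in either direction.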